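Compound 3 to compound 4: an aryl exchange

The compounds below may be only part of what the source reports. "The series", "measured", "known", "first", "only" and "open" are said of these compounds alone.

In a functional assay on A549 cells (Homo sapiens) for cytotoxicity, read by MTT assay, with a stated time of 48 h (a lower number here means a stronger inhibitor, a higher number a weaker inhibitor), compound 1 (`CC1(C)CCC[C@]2(C)[C@@H](CC[C@@](C)(O)/C=C/c3ccc(Cl)nc3)[C@](C)(O)CC[C@@H]12`) gives 3280 nM, compound 2 (`CC(C)(C)c1ccc(/C=C/[C@](C)(O)CC[C@@H]2[C@@]3(C)CCCC(C)(C)[C@@H]3CC[C@@]2(C)O)cc1`) gives 45000 nM and compound 3 (`COc1cccc(/C=C/[C@](C)(O)CC[C@@H]2[C@@]3(C)CCCC(C)(C)[C@@H]3CC[C@@]2(C)O)c1OC`) gives 3280 nM. Compound 3 therefore stands level with compound 1, well under compound 2. Compound 4 (`Cc1cccc(C)c1/C=C/[C@](C)(O)CC[C@@H]1[C@@]2(C)CCCC(C)(C)[C@@H]2CC[C@@]1(C)O`) differs from compound 3 as follows: 2,6-dimethylphenyl in place of 2,3-dimethoxyphenyl on a double-bonded chain carbon bound to a double-bonded chain carbon. Two measured exchanges at this place bear on it: no change at the digits printed from compound 1 to compound 3 (within the scatter), and a 14-fold lower number from compound 2 to compound 3 (1.14 log units; beyond the scatter). The group in compound 2 is also built of carbon only, so part of that large step is expected to return, though not all of it. The estimated step is a 2.4-fold higher number from compound 3 to compound 4 (0.39 log units; beyond the scatter). For compound 4 the expected value is 8000 nM, with an estimated range of 2500 nM to 30000 nM.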

Compound 4, half-maximal inhibitory concentration: 3340 nM
Compound 4: the middle estimate sits 2.4-fold (0.38 log units) above what was measured; the range from low to high includes it.
By their numbers in this assay, from the lowest: compounds 1, 3 and 4 (each within the scatter of the next); then compound 2.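

In this assay, 2,6-dimethylphenyl, which carries no oxygen and no hydrogen-bond acceptors, can replace 2,3-dimethoxyphenyl with a 1.0-fold higher number from compound 3 to compound 4 (0.01 log units; within the scatter), so the oxygens of compound 3 are not required at this place. The same holds for 6-chloropyridin-3-yl, with a 1.0-fold higher number from compound 1 to compound 4 (0.01 log units; within the scatter), while a 13-fold lower number from compound 2 to compound 4 (1.13 log units; beyond the scatter) shows that a carbon-only aryl group does not by itself bring the weak result of compound 2. No measurement shown here accounts for the gap between these two carbon-only groups. Still open, on these data alone, is how an unsubstituted phenyl, or an aryl group bearing an amine or a carboxylic acid, would read at this place.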